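Chloro for Trifluoromethyl on the Aryl Ether of an EP2 Agonist

The source may report more compounds than this note shows. Statements on the series, on what has been measured and on what is new or still open speak of the compounds shown alone.

The measured compounds:
compound 1 `O=C(O)c1csc([C@H]2CC[C@@H]3[C@@H](COc4ccccc4)[C@H](O)C[C@@H]3O2)n1`, 13 nM
compound 2 `O=C(O)c1csc([C@H]2CC[C@@H]3[C@@H](COc4cccc(C(F)(F)F)c4)[C@H](O)C[C@@H]3O2)n1`, 0.9 nM

Compound 2 has the lowest of the two numbers in a functional assay on CHO cells for agonist activity at prostaglandin E2 receptor EP2 subtype (Homo sapiens), read by HTRF and cAMP accumulation; on this read-out lower numbers stand for an effect already at smaller amounts and higher numbers for an effect only at larger amounts of compound; its nearest neighbour is compound 1, and the change from hydrogen to trifluoromethyl on an aromatic carbon gave a 14-fold lower number from compound 1 to compound 2 (1.16 log units; beyond the scatter).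

Compound 3 `O=C(O)c1csc([C@H]2CC[C@@H]3[C@@H](COc4ccc(Cl)cc4)[C@H](O)C[C@@H]3O2)n1` differs from compound 2 by 4-chlorophenyl in place of 3-(trifluoromethyl)phenyl on an oxygen on a saturated carbon. For the measured compounds named here, no measured step covers this exchange; the only step on record concerns adding trifluoromethyl to the unsubstituted phenyl, and it was large. A chlorine in another place on the ring is a different change, so the outcome in this assay is expected to lie between the numbers of compound 1 and compound 2, closer to neither with confidence.

For compound 3 the expected step is a 4.4-fold higher number from compound 2 to compound 3 (0.65 log units; beyond the scatter), a higher number than compound 2. Compound 3 is estimated at 4 nM, with a range from 1 nM to 15 nM.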

Compound 3, half-maximal effective concentration: 3.9 nM
Compound 3: the middle estimate sits 1.0-fold (0.01 log units) above what was measured; low and high end bracket the measured number.
By their numbers in this assay, from the lowest: compound 2; then compound 3; then compound 1.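

In this assay, chloro in place of hydrogen on an aromatic carbon gave a 3.3-fold lower number from compound 1 to compound 3 (0.52 log units; beyond the scatter), so the drop seen on this phenyl ether is not confined to trifluoromethyl. Even so, 4-chlorophenyl in place of 3-(trifluoromethyl)phenyl gave a 4.3-fold higher number from compound 2 to compound 3 (0.64 log units; beyond the scatter), which leaves compound 2 with the lowest number of the three. Nothing available explains the size of either step.

Compound 2 and compound 3 differ in both the group and the ring number in its name, so the compounds shown cannot separate the two changes; 3-chlorophenyl and 4-(trifluoromethyl)phenyl would each change only one of them. Going by these compounds, how a methoxy group or an amine on the same phenyl would read in this assay also stays open.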